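Alpha-methylation of the leucine core in a nitrile series

The compounds below may be only part of what the source reports. "The series", "measured", "known", "first", "only" and "open" are said of these compounds alone.

Measured so far:
- compound 1 `CC(C)C[C@H](NC(=O)N1CCOCC1)C(=O)NCC#N`; in an assay for inhibition of cathepsin S (Homo sapiens) (on this read-out lower numbers stand for stronger inhibition and higher numbers for weaker inhibition), compound 1 gives 124 nM
- compound 2 `CC(C)C[C@H](NC(=O)N1CCOCC1)C(=O)N[C@@H](C)C#N`; in this assay compound 2 gives 142 nM
- compound 3 `CC(C)C[C@@H](NC(=O)N1CCOCC1)C(=O)N[C@H](C#N)CCc1ccccc1`; in this assay compound 3 gives 11000 nM

Compound 1 and compound 2 differ in one place: methyl in place of hydrogen on a saturated chain carbon bound to an amide-type nitrogen and a triple-bonded carbon. The step is a 1.1-fold higher number from compound 1 to compound 2 (0.06 log units; within the scatter), so the two numbers cannot be told apart.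

Compound 3 carries a different core. How the core of compound 3 differs from the core of compound 1 is not broken down here; what can be said is that compound 3 stands highest of the three, and its gap to each of compound 1 and compound 2 lies well beyond the scatter.

The unmeasured compound 4 `CC(C)C[C@](C)(NC(=O)N1CCOCC1)C(=O)N[C@H](C#N)CCc1ccccc1` is derived from compound 3 by methyl in place of hydrogen on a saturated chain carbon bound to an amide-type nitrogen, a carbonyl carbon and a saturated chain carbon. This is the same kind of change as between compound 1 and compound 2, but not the same: there the place was a saturated chain carbon bound to an amide-type nitrogen and a triple-bonded carbon, here it is a saturated chain carbon bound to an amide-type nitrogen, a carbonyl carbon and a saturated chain carbon. Among the compounds with values here, the only precedent for adding a methyl is the step from compound 1 to compound 2, which was within the scatter.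

In this assay the expected step is a 1.5-fold higher number from compound 3 to compound 4 (0.16 log units; within the scatter), placed beside that earlier one but with a wide range, since the surroundings of the place differ and compound 3 already sits far above the other two. The estimate for compound 4 is 16000 nM, with a range from 4000 nM to 70000 nM.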

Compound 4, half-maximal inhibitory concentration: 76000 nM
For compound 4 the middle estimate is 4.8-fold (0.68 log units) below the measured one, outside the stated range (above it).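

On the core of compound 3, methyl in place of hydrogen gives a 6.9-fold higher number from compound 3 to compound 4 (0.84 log units; beyond the scatter) in this assay, and the two methyl steps available do not agree in size: the same change on two cores in this assay, a 1.1-fold higher number (0.06 log units; within the scatter) from compound 1 to compound 2 and a 6.9-fold higher number (0.84 log units; beyond the scatter) from compound 3 to compound 4, 6.0-fold (0.78 log units) apart, beyond the scatter of two such steps. A single earlier step therefore gives no reliable size for this change on another core in this series: the step from compound 1 to compound 2 is silent, while the step to compound 4 raises a number that already stood high, with compound 3 at 11000 nM. What the pair does not show is whether the core or the place accounts for the gap, since the methyl sits on a saturated chain carbon bound to an amide-type nitrogen and a triple-bonded carbon in compound 2, but on a saturated chain carbon bound to an amide-type nitrogen, a carbonyl carbon and a saturated chain carbon in compound 4.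

Open, from the compounds shown here alone, is what a methyl at the place used in compound 4 does on the core of compound 1, a comparison that would hold the place fixed and vary only the core. Also open, going by these compounds, is whether a longer chain such as ethyl, or a hydroxymethyl group, at that same carbon would follow the methyl step or depart from it.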